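A few compounds are considered here, and "the series" means these few. Any claim that something is new, unique, unknown or untested is made for them only; others in the source may bear on it.

Measured so far:
compound 1, `CCCCCCCCc1cn(C(c2ccccc2)c2cc3cc(Br)ccc3nc2OC)nn1`: 12.1%
compound 2, `CCOC(=O)c1cn(C(c2ccccc2)c2cc3cc(Br)ccc3nc2OC)nn1`: 15.4%
compound 3, `CCCCCc1cn(C(c2ccccc2)c2cc3cc(Br)ccc3nc2OC)nn1`: 5.07%

In an ADME assay on PANC-1 cells (Homo sapiens) for cytotoxicity, read by sulforhodamine B assay, with a stated time of 48 h, tested at 10 uM (on this read-out higher numbers stand for more inhibition at the one concentration tested (going by the name of the read-out) and lower numbers for less inhibition), compound 1 gives 12.1% and stands second highest of the three numbers. Its nearest neighbour is a number 3.3 percentage points higher from compound 1 to compound 2 (within the scatter); its furthest is a number 7 percentage points lower from compound 1 to compound 3 (within the scatter). Both gaps lie within the scatter, so the three compounds are not separated around compound 1. Going by the values given here, the only step beyond the scatter is a number 10.3 percentage points lower from compound 2 to compound 3 (beyond the scatter), and even that is modest.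

Compound 4, `COc1nc2ccc(Br)cc2cc1C(c1ccccc1)n1cc(-c2ccc(F)cc2)nn1`, is not yet measured. It differs from compound 1 in one place: 4-fluorophenyl in place of octyl on an aromatic carbon. The measured steps that touch the same aromatic carbon are a number 3.3 percentage points higher from compound 1 to compound 2 (within the scatter) and a number 10.3 percentage points lower from compound 2 to compound 3 (beyond the scatter); the chain-shortening step a number 7 percentage points lower from compound 1 to compound 3 (within the scatter) stayed within the scatter. Among the compounds with values here, none of these brings in a ring, so no direct precedent exists for the group that enters. The steps seen so far are small, and the expected step is likewise small: a number 0.9 percentage points higher from compound 1 to compound 4 (within the scatter). For compound 4 the estimate in this assay is 13%, expected to fall between 3% and 27%.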

Compound 4, a percentage reported as inhibition, at one concentration (the size of the read-out at that concentration, not a potency): 14.9%
Compound 4: the middle estimate sits 1.9 percentage points below what was measured, within the range that was stated.
By their numbers in this assay, from the lowest: compounds 3, 1, 4 and 2 (each within the scatter of the next, the first and the last beyond it).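

In this assay, going by these compounds alone, the aromatic carbon of the five-membered ring carries a ring for the first time, and 4-fluorophenyl cannot be told apart from the chains or the ester: a number 2.8 percentage points higher from compound 1 to compound 4 (within the scatter), a number 9.8 percentage points higher from compound 3 to compound 4 (within the scatter), and a number 0.5 percentage points lower from compound 2 to compound 4 (within the scatter). Compound 4 therefore lies within the scatter of both compound 2 and compound 3, although those two are separated by a step beyond it. At this position, a six-membered aromatic ring of carbon only thus gives no reading separable from octyl, pentyl or ethoxycarbonyl.

From the compounds shown here alone, whether a primary amine or a carboxylic acid on this carbon would give a reading beyond the scatter from compound 4 remains open. No measurement at hand accounts for any of these readings.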